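The compounds below may be only part of what the source reports. "The series", "measured", "known", "first", "only" and "open" are said of these compounds alone.

Compound 1 `CCCCNc1nc(N)nc2c1CN(Cc1ccccc1)CC2` is one of three closely related compounds tested in an assay on HEK293 cells for agonist activity at Toll-like receptor 8 (Homo sapiens), read by a luciferase reporter, with a stated time of 6 h (on this read-out higher numbers stand for an effect only at larger amounts of compound and lower numbers for an effect already at smaller amounts), where compound 1 gives 0.06 uM. Among these three numbers it stands second highest. Compound 3 `CCCCNc1nc(N)nc2c1CN(Cc1ccccc1Cl)CC2` lies nearest, with 0.05 uM, and the step of a 1.2-fold lower number from compound 1 to compound 3 (0.08 log units; within the scatter) is within the scatter. Compound 2 `CCCCNc1nc(N)nc2c1CN(S(C)(=O)=O)CC2` lies furthest, giving 9.9 uM; the step of a 170-fold higher number from compound 1 to compound 2 (2.22 log units; beyond the scatter) is a large loss, showing that the benzyl group on the ring amine matters a great deal for this read-out.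

Compound 4 `CCCCNc1nc(N)nc2c1CN(Cc1ccc(C(F)(F)F)cc1)CC2` differs from compound 1 by trifluoromethyl in place of hydrogen on an aromatic carbon. The most telling precedent is the step from compound 1 to compound 3, where a chloro on the same benzyl ring left the number within the scatter. The benzyl itself is kept in compound 4, so the large loss seen on going to compound 2 should not apply. The expectation is therefore a step no larger than the scatter, a 1.3-fold higher number from compound 1 to compound 4 (0.12 log units; within the scatter), and compound 4 is estimated at 0.08 uM, with a plausible range from 0.03 uM to 0.25 uM.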

Compound 4, minimum effective concentration: 0.23 uM
Beside the measured number, compound 4's estimate is 2.9-fold (0.46 log units) below it, and the stated range covers the measured number.
By their numbers in this assay, from the lowest: compounds 3 and 1 (each within the scatter of the next); then compound 4; then compound 2.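

In this assay, placing trifluoromethyl on an aromatic carbon of the benzyl ring, para to a large group, brings a 3.8-fold higher number from compound 1 to compound 4 (0.58 log units; beyond the scatter), a modest step. The earlier result, a 1.2-fold lower number from compound 1 to compound 3 (0.08 log units; within the scatter), suggested that this ring accepts an added group with no clear change, but compound 4 shows that this does not hold for every group and place on the ring. No measurement at hand explains why this step occurs.

Chloro and trifluoromethyl differ both as groups and in where they sit on the ring, so the compounds shown cannot separate these two changes. From the compounds shown here alone, it also remains open whether a fluoro, a methoxy, an amine or a carboxylic acid on this same carbon would keep the number close to that of compound 1.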